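The compounds below may be only part of what the source reports. "The series", "measured", "known", "first", "only" and "open" are said of these compounds alone.

The measured compounds and their values in a functional assay on OVCAR-3 cells (Homo sapiens) for inhibition, read by MTT assay, with a stated time of 24 h; a lower number here means a stronger inhibitor, a higher number a weaker inhibitor:

compound 1 `CC1(C)[C@H]2CC[C@]1(C)N(Cc1cn(-c3ccc(Cl)cc3)nn1)C(=O)C2` — 160 nM
compound 2 `CC1(C)[C@H]2CC[C@]1(C)N(Cc1cn(-c3ccccc3Br)nn1)C(=O)C2` — 140 nM
compound 3 `CC1(C)[C@H]2CC[C@]1(C)N(Cc1cn(-c3ccc(F)cc3)nn1)C(=O)C2` — 200 nM

All three share one core and differ only in the substituted phenyl that sits on an aromatic nitrogen. Compound 1 gives the second highest of the three numbers in this assay; its nearest neighbour is compound 2, with a 1.1-fold lower number from compound 1 to compound 2 (0.06 log units; within the scatter), and the furthest is compound 3, with a 1.3-fold higher number from compound 1 to compound 3 (0.10 log units; within the scatter). The remaining pair, a 1.4-fold higher number from compound 2 to compound 3 (0.15 log units; within the scatter), is likewise within the scatter, so the three phenyl variants are not distinguished by the data.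

Compound 4 `CC1(C)[C@H]2CC[C@]1(C)N(Cc1cn(-c3ccc(C#N)cc3)nn1)C(=O)C2` is not yet measured. It differs from compound 1 by cyano in place of chloro on an aromatic carbon. The step that bears most directly on this change is the exchange of one halogen for another on the same aromatic carbon, a 1.3-fold higher number from compound 1 to compound 3 (0.10 log units; within the scatter), which stayed within the scatter; the changes of position and halogen in the other two steps did likewise. On that basis no step beyond the scatter is expected, and the estimated value for compound 4 in this assay is 180 nM, with a range from 90 nM to 360 nM, corresponding to an expected step of a 1.1-fold higher number from compound 1 to compound 4 (0.05 log units; within the scatter).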

Compound 4, half-maximal inhibitory concentration: 380 nM
For compound 4 the middle estimate is 2.1-fold (0.32 log units) below the measured one; measured number above the stated range.
By their numbers in this assay, from the lowest: compounds 2, 1, 3 and 4 (each within the scatter of the next, the first and the last beyond it).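

Going by these compounds alone, at this aromatic carbon in this assay, cyano in place of chloro gives the first steps to pass the scatter, though only modestly (a 2.4-fold higher number from compound 1 to compound 4 (0.38 log units; beyond the scatter)), and the exchange of 2-bromophenyl for 4-cyanophenyl does the same (a 2.7-fold higher number from compound 2 to compound 4 (0.43 log units; beyond the scatter)). Against the fluoro compound, the exchange stays within the scatter (a 1.9-fold higher number from compound 3 to compound 4 (0.28 log units; within the scatter)), so compound 4 stands apart from compound 1 and compound 2 but not from compound 3. Nothing shown explains the difference.

On these data alone, it remains open whether the higher number is particular to cyano or would also follow an amine, a carboxylic acid or a methoxy group on this carbon. Also open, as far as these compounds go, is how cyano would read at another carbon of the same ring.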